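The source may hold more compounds than are shown below. What is called first, only, known or untested is meant among the compounds shown, and "the series" means these compounds.

Compound 3 `Cc1nc(S(C)(=O)=O)ccc1Oc1ncnc(OC2CCN(C(=O)C3(F)CCC3)CC2)c1F` stands in a functional assay on isolated protein for inhibition of Glucose-dependent insulinotropic receptor (Homo sapiens), read by HTRF and cAMP accumulation (on this read-out lower numbers stand for an effect already at smaller amounts and higher numbers for an effect only at larger amounts of compound), at 24.7 nM; compound 2 `Cc1nc(S(C)(=O)=O)ccc1Oc1ncnc(OC2CCN(C(=O)SC3CC3)CC2)c1F` lies within the scatter of it at 24.9 nM, while compound 1 `Cc1nc(S(C)(=O)=O)ccc1Oc1ncnc(OC2CCN(C(=O)O[C@H](C)CF)CC2)c1F` stands well apart at 196 nM. Compound 4 `Cc1nc(S(C)(=O)=O)ccc1Oc1ncnc(OC2CCN(C(=O)c3noc(C(C)C)n3)CC2)c1F` differs from compound 3 by a group of 8 heavy atoms (5 carbon, 2 nitrogen, 1 oxygen; one five-membered aromatic ring with 3 hetero atoms) in place of a group of 5 heavy atoms (4 carbon, 1 fluorine; one four-membered non-aromatic ring of carbon only), on a carbonyl carbon. Going by the values given here, two measured steps bear on this: a 7.9-fold lower number from compound 1 to compound 2 (0.90 log units; beyond the scatter) and a 7.9-fold lower number from compound 1 to compound 3 (0.90 log units; beyond the scatter), each putting a ring in place of a chain on the carbonyl carbon, and one more, the exchange of one ring for another, a 1.0-fold lower number from compound 2 to compound 3 (0.00 log units; within the scatter), which stayed within the scatter. A ring remains on the carbonyl carbon in compound 4, so the expected step is a 1.2-fold higher number from compound 3 to compound 4 (0.08 log units; within the scatter), likely not beyond the scatter. Compound 4 is estimated at 30 nM, between 10 nM and 100 nM.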

Compound 4, half-maximal effective concentration: 21.2 nM
Estimate against measurement, compound 4: 1.4-fold (0.15 log units) above; the measured number falls inside the stated range.
By their numbers in this assay, from the lowest: compounds 4, 3 and 2 (each within the scatter of the next); then compound 1.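

On the carbonyl carbon whose other neighbour is the amide-type nitrogen in a ring, the aromatic 5-isopropyl-1,2,4-oxadiazol-3-yl group, which carries hydrogen-bond acceptors, reads alike with the non-aromatic rings: a 1.2-fold lower number from compound 3 to compound 4 (0.07 log units; within the scatter) and a 1.2-fold lower number from compound 2 to compound 4 (0.07 log units; within the scatter). Against the open chain of compound 1, the same group gives a 9.2-fold lower number from compound 1 to compound 4 (0.97 log units; beyond the scatter), so compounds 2, 3 and 4 stand together, apart from compound 1. Nothing available explains why these different rings read alike. From the compounds shown here alone, whether an amine, a carboxylic acid or a longer carbon chain on this carbonyl carbon would read the same remains open.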